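Swapping an Oxane for an Oxazole on the Shared Core

The source may hold more compounds than are shown below. What is called first, only, known or untested is meant among the compounds shown, and "the series" means these compounds.

Three compounds have been measured in an assay on HEK293 cells for inhibition of N-acylethanolamine-hydrolyzing acid amidase (Homo sapiens), read by fluorescence, with stated times of 10 min and 50 min; on this read-out higher numbers stand for weaker inhibition and lower numbers for stronger inhibition:
compound 1 `CCCc1ccc(COC(=O)N[C@H]2CNC2=O)cc1` gives 52 nM;
compound 2 `CC(OC(=O)N[C@H]1CNC1=O)c1ccc(C2CCCCC2)cc1` gives 4470 nM;
compound 3 `O=C(N[C@H]1CNC1=O)OCc1ccc(C2CCOCC2)cc1` gives 1370 nM.

Compound 3 stands second highest of the three numbers in this assay. For the measured compounds named here, its nearest neighbour is compound 2, whose number is higher, and the one step that reaches compound 3 directly is the large one from compound 1, a 26-fold higher number from compound 1 to compound 3 (1.42 log units; beyond the scatter), where oxan-4-yl took the place of propyl on an aromatic carbon.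

Compound 4 `O=C(N[C@H]1CNC1=O)OCc1ccc(-c2cocn2)cc1` is the next variation on the shared core. Compared with compound 3, the change is 1,3-oxazol-4-yl in place of oxan-4-yl on an aromatic carbon, placed on an aromatic carbon of a six-membered aromatic ring of carbon only, para to a large group.

Going by the values given here, no measured step swaps one ring for another at this position; the only step that touches this part of the molecule is the one from compound 1 to compound 3, and it exchanged a chain for a ring rather than a ring for a ring. It therefore gives no direction for the present change, and the expectation for compound 4 in this assay is a step of a 1.1-fold lower number from compound 3 to compound 4 (0.06 log units; within the scatter), which is not expected to reach beyond the scatter. Compound 4 is estimated at 1200 nM, within a range from 250 nM to 6000 nM.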

Compound 4, half-maximal inhibitory concentration: 1880 nM
Compound 4: the middle estimate sits 1.6-fold (0.19 log units) below what was measured; the range from low to high includes it.
By their numbers in this assay, from the lowest: compound 1; then compounds 3 and 4 (each within the scatter of the next); then compound 2.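

In this assay, this first exchange of one ring for another at this position gives a 1.4-fold higher number from compound 3 to compound 4 (0.14 log units; within the scatter), so the six-membered non-aromatic ring of oxan-4-yl and the five-membered aromatic ring of 1,3-oxazol-4-yl cannot be told apart on this read-out. With propyl as the reference, 1,3-oxazol-4-yl gives a 36-fold higher number from compound 1 to compound 4 (1.56 log units; beyond the scatter), which places a second, different ring on the same side of the large gap already seen with oxan-4-yl in a 26-fold higher number from compound 1 to compound 3 (1.42 log units; beyond the scatter), and among the compounds that differ in this one place, no ring matches the propyl chain. Nothing available explains why either ring stands so far from propyl, or why the two rings cannot be separated.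

The compounds shown leave open whether a butyl chain or a small cyclopropyl ring on the same aromatic carbon would fall near compound 1 or near compounds 3 and 4. They also leave open how a cyclohexyl ring would behave on the unchanged core, as compound 2 carries that ring together with an added methyl group and so differs from the others in more than one place.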